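Methyl for methoxy on the aryl-bearing analogue

The source may report more compounds than this note shows. Statements on the series, on what has been measured and on what is new or still open speak of the compounds shown alone.

compound 1 `CC(CC(=N)S)n1ncccc1=O`: 38.8%
compound 2 `COc1ccc(-c2ccc(=O)n(CCC(=N)S)n2)cc1`: 20.7%
compound 3 `C/N=C(\S)CC(C)n1ncccc1=O`: 42.7%

All three numbers come from a functional assay on the whole organism (stomach) for inhibition, with Rattus norvegicus as the target, at a dose of 100 mg/kg by the intraduodenal route; a higher number here means more inhibition at the dose given (going by the name of the read-out), a lower number less inhibition. Compound 2 stands lowest of the three; its value sits beyond the scatter under both compound 1 and compound 3. Compound 4 `Cc1ccc(-c2ccc(=O)n(CCC(=N)S)n2)cc1` is compound 2 with methyl in place of methoxy on an aromatic carbon. For the measured compounds named here, the one measured step, a number 3.9 percentage points higher from compound 1 to compound 3 (within the scatter), concerns a different change on a different core and does not bear on this one; nothing measured speaks to methyl against methoxy. The expectation is therefore no step beyond the scatter, with a number 1.3 percentage points higher from compound 2 to compound 4 (within the scatter) estimated as the change. Compound 4 is estimated at 22% in this assay, in the range 8% to 38%.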

Compound 4, a percentage reported as inhibition, in the whole organism at one dose (the size of the read-out at that dose, not a potency): 18.2%
Compound 4: middle estimate off by 3.8 percentage points, on the high side; the measured number falls inside the stated range.
By their numbers in this assay, from the lowest: compounds 4 and 2 (each within the scatter of the next); then compounds 1 and 3 (each within the scatter of the next).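

In this assay, methyl in place of methoxy on an aromatic carbon, para to a large group, gives a number 2.5 percentage points lower from compound 2 to compound 4 (within the scatter). At this position, the change removes the one hydrogen-bond acceptor counted on the methoxy without a step beyond the scatter. No available measurement bears on why this step stays within the scatter.

As far as these compounds go, whether an amine or a carboxylic acid at this place would give a step beyond the scatter remains open. Also open, from the compounds shown here alone, is whether the change from compound 1 to compound 3 would read the same on the core of compound 2.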